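The source may hold more compounds than are shown below. What is called first, only, known or untested is meant among the compounds shown, and "the series" means these compounds.

Measured so far in a functional assay on Ehrlich cells (Mus musculus) for cytotoxicity, tested at 50 ug/mL; a lower number here means a weaker effect, a higher number a stronger effect of the compound at the concentration tested: compound 1 `COc1cc(N2C(N)=C(C#N)C(c3ccc([N+](=O)[O-])cc3)C3=C2CC(C)(C)CC3=O)cc(OC)c1OC` gives 70%; compound 2 `COc1ccccc1C1C(C#N)=C(N)N(c2cc(OC)c(OC)c(OC)c2)C2=C1C(=O)CC(C)(C)C2` gives 70%; compound 3 `COc1cc(N2C(N)=C(C#N)C(c3ccc(C)cc3)C3=C2CC(C)(C)CC3=O)cc(OC)c1OC` gives 60%.

Compound 3 is not set apart from either neighbour beyond the scatter: the steps of a number 10 percentage points lower from compound 1 to compound 3 (within the scatter) and a number 10 percentage points lower from compound 2 to compound 3 (within the scatter) are both small. Compound 4 `COc1cc(N2C(N)=C(C#N)C(c3ccc(O)cc3)C3=C2CC(C)(C)CC3=O)cc(OC)c1OC` differs from compound 3 by hydroxy in place of methyl on an aromatic carbon. Among the compounds with values here, two measured steps bear on this change, both at the same aryl group on the saturated ring carbon: a number 10 percentage points lower from compound 1 to compound 3 (within the scatter) and a number 10 percentage points lower from compound 2 to compound 3 (within the scatter), neither leaving the scatter. Since swaps of the group on that aryl ring have so far moved this assay by nothing beyond the scatter, a step of a number 5 percentage points higher from compound 3 to compound 4 (within the scatter) is expected for compound 4. Compound 4 is therefore estimated at 65%, with a range from 50% to 80%.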

Compound 4, a percentage reported as activity, at one concentration (the size of the read-out at that concentration, not a potency): 90%
For compound 4 the middle estimate is 25 percentage points below the measured one; the measured number lies above the stated range.
By their numbers in this assay, from the lowest: compounds 3, 1 and 2 (each within the scatter of the next); then compound 4.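

In this assay, the group on this aromatic ring does matter: hydroxy in place of methyl gives a number 30 percentage points higher from compound 3 to compound 4 (beyond the scatter), hydroxy in place of nitro gives a number 20 percentage points higher from compound 1 to compound 4 (beyond the scatter), and 4-hydroxyphenyl in place of 2-methoxyphenyl gives a number 20 percentage points higher from compound 2 to compound 4 (beyond the scatter). Compound 4 is thus the only one set apart from the rest, while the other three remain within the scatter of each other. Nothing shown here explains why hydroxy stands apart.

From the compounds shown here alone, it remains open whether an amine or a carboxylic acid at the same place would match hydroxy. The hydroxy group's placement on the ring is also untested, since only one position is shown.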